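Replacing 4-methoxyphenyl with pyridin-2-yl on the shared core

The source may hold more compounds than are shown below. What is called first, only, known or untested is meant among the compounds shown, and "the series" means these compounds.

In an ADME assay on MDBK cells (Bos taurus) for cytotoxicity, read by MTT assay, with a stated time of 96 h (a higher number here means that more compound is tolerated, a lower number that less compound is tolerated), compound 1 `CC(=O)c1ccc2c(c1)nc(-c1ccccn1)n2C1CCCCC1` gives > 100000 nM as a limit of the assay and not a number. Compound 2 `C/C(=N\NC(N)=S)c1ccc2c(c1)nc(-c1ccc(C(F)(F)F)cc1)n2C1CCCCC1` also reaches only a limit with > 100000 nM as its reading. Going by the values given here, compound 3 `COc1ccc(-c2nc3cc(/C(C)=N/NC(N)=S)ccc3n2C2CCCCC2)cc1` stands apart with 32000 nM as the only actual number among the three.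

Compound 4 `C/C(=N\NC(N)=S)c1ccc2c(c1)nc(-c1ccccn1)n2C1CCCCC1` is still unmeasured. It carries pyridin-2-yl in place of 4-methoxyphenyl on an aromatic carbon of a five-membered aromatic ring with 2 nitrogen, between two ring nitrogen atoms and next to the ring atom that bears a cyclohexyl group (pyridin-2-yl in place of 4-methoxyphenyl on an aromatic carbon).

Among the compounds with values here, one measured step bears on this change. With methoxy in place of trifluoromethyl on an aromatic carbon, an at least 3.1-fold lower number from compound 2 to compound 3 (0.49 log units; beyond the scatter) marks a drop beyond the scatter. Compound 4 gives up that methoxy as well, so the step seen with compound 3 suggests a move back towards more compound being tolerated. The reading may stop at the limit of > 100000 nM in this assay, at which 2 of the 3 values shown sit, and so could be a limit rather than a number.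

The expected step in this assay is a 1.9-fold higher number from compound 3 to compound 4 (0.27 log units; within the scatter) and it is modest in size. Compound 4 is estimated at 60000 nM within an expected range of 20000 nM to 100000 nM at its two ends.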

Compound 4, half-maximal cytotoxic concentration: 41000 nM
Compound 4: the middle estimate sits 1.5-fold (0.17 log units) above what was measured; low and high end bracket the measured number.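

In this assay, pyridin-2-yl in place of 4-methoxyphenyl, on the aromatic carbon between two ring nitrogen atoms, gives a 1.3-fold higher number from compound 3 to compound 4 (0.11 log units; within the scatter), so the two groups cannot be told apart here, and a reading below the limit does not depend on the methoxy group that marked compound 3. Compound 4 also separates from the compound carrying 4-(trifluoromethyl)phenyl at this place, with an at least 2.4-fold lower number from compound 2 to compound 4 (0.38 log units; beyond the scatter), and with pyridin-2-yl held fixed, the group of 7 heavy atoms (3 carbon, 3 nitrogen, 1 sulfur; no ring) in place of the group of 3 heavy atoms (2 carbon, 1 oxygen; no ring) gives an at least 2.4-fold lower number from compound 1 to compound 4 (0.38 log units; beyond the scatter), which shows that a change at this second place also moves the reading. Both of these steps start from a limit, so they give only a smallest size: the limit of > 100000 nM in this assay, at which 2 of the 4 values shown sit.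

The compounds shown leave open how an unsubstituted phenyl, pyridin-3-yl or a ring bearing an amine or a carboxylic acid would read at this place. They also leave open how far compound 1 and compound 2 truly lie from compound 4.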